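Phenethyl for 4-ethylphenyl on a sulfur

The source may hold more compounds than are shown below. What is called first, only, known or untested is meant among the compounds shown, and "the series" means these compounds.

Among the measured compounds shown here, only one number is available in this small series. In a functional assay on HCT-116 cells (Homo sapiens) for antiproliferative activity, read by CCK-8 assay, with a stated time of 72 h (on this read-out lower numbers stand for stronger inhibition and higher numbers for weaker inhibition), compound 1 (`CCc1ccc(SCc2ccc(C(=O)Nc3ccccc3N)cc2)cc1`) gives 1740 nM and stands alone, with no other measured value to rank it against. Compound 2 (`Nc1ccccc1NC(=O)/C=C/c1ccc(CSc2cccc3ccccc23)cc1`) carries the entry "not determined" (no result reported) in this assay and offers no comparison. Compound 3 (`Nc1ccccc1NC(=O)/C=C/c1ccc(CSCCc2ccccc2)cc1`) carries the entry "not determined" (no result reported) in this assay and likewise offers none, although it also bears a phenethyl group on sulfur.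

Compound 4 (`Nc1ccccc1NC(=O)c1ccc(CSCCc2ccccc2)cc1`) is the unmeasured partner of compound 1. The two have the same atoms, joined differently, with phenethyl in place of 4-ethylphenyl on a sulfur. For the measured compounds named here, the two groups match in everything counted, and no measured pair shows what such an exchange does. Going by the values given here, the only anchor is compound 1 at 1740 nM and so no change beyond the usual scatter is expected in this assay and neither direction is favoured. The expected step is correspondingly small (a 1.0-fold higher number from compound 1 to compound 4 (0.01 log units; within the scatter)). For compound 4 the estimated value is 1800 nM with an expected range of 600 nM to 5400 nM around it.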

Compound 4, half-maximal inhibitory concentration: 2810 nM
For compound 4 the middle estimate is 1.6-fold (0.19 log units) below the measured one; low and high end bracket the measured number.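

The series now has its first measured step in this assay: putting phenethyl in place of 4-ethylphenyl on a sulfur gives a 1.6-fold higher number from compound 1 to compound 4 (0.21 log units; within the scatter). Compound 1 and compound 4 therefore cannot be told apart on this read-out, and the sulfur carries either of these two groups, which match in everything counted, without a difference that stands clear of the usual scatter. No evidence is available that bears on this result.

From the compounds shown here alone, it remains open whether a group of another kind on the sulfur, such as a chain ending in an amine or a carboxylic acid, or a longer chain ending in phenyl, would move the number beyond the scatter. Among the compounds shown here, a single pair also cannot show whether the same exchange of 4-ethylphenyl and phenethyl would read alike on a core other than the one shared by compound 1 and compound 4.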